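The source may report more compounds than this note shows. Statements on the series, on what has been measured and on what is new or still open speak of the compounds shown alone.

Measured so far:
Compound 1, `OCc1cc(OCc2cc(O)ccc2O)cc(Cl)c1O`, 5300 nM
Compound 2, `OCc1cc(OCc2cc(O)ccc2O)ccc1O`, 54700 nM
Compound 3, `COCc1cc(O)cc(Cl)c1O`, 6700 nM

In a functional assay on HL-60 cells (Homo sapiens) for cytotoxicity, read by MTT assay (a lower number here means a stronger inhibitor, a higher number a weaker inhibitor), the change from compound 1 to compound 2, (hydrogen in place of chloro on an aromatic carbon), produced a 10-fold higher number from compound 1 to compound 2 (1.01 log units; beyond the scatter). Compound 3 is built on a different core; the difference between the two cores is not broken down here. Compound 4, `COCc1cc(O)ccc1O`, is not yet measured and differs from compound 3 by hydrogen in place of chloro on an aromatic carbon. Around the place the surroundings are not identical: in the pair of compound 1 and compound 2 the carbon is meta to a hydroxymethyl group and meta to a large group, whereas in the pair of compound 3 and compound 4 it is meta to a methoxymethyl group; so this is the same kind of change, not the same change. Resting on the step seen from compound 1 to compound 2, the step from compound 3 to compound 4 in this assay is expected to be an 8.2-fold higher number from compound 3 to compound 4 (0.91 log units; beyond the scatter). Compound 4 is therefore estimated at 55000 nM, between 15000 nM and 170000 nM.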

Compound 4, half-maximal inhibitory concentration: 58900 nM
Compound 4: middle estimate off by 1.1-fold (0.03 log units), on the low side; measured number inside the range.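

In this assay, hydrogen in place of chloro on the aromatic carbon gave an 8.8-fold higher number from compound 3 to compound 4 (0.94 log units; beyond the scatter), and this step can be set against the earlier one on the other core: the same change on two cores in this assay, a 10-fold higher number (1.01 log units; beyond the scatter) from compound 1 to compound 2 and an 8.8-fold higher number (0.94 log units; beyond the scatter) from compound 3 to compound 4, 1.2-fold (0.07 log units) apart, within the scatter of two such steps. In these two pairs, therefore, the loss of chloro carried over from one core to the other with a size that cannot be told apart. This rests on two pairs alone; it does not show that the step would hold on any further core, and it says nothing of its cause.

The compounds shown leave open whether bromo, methyl or an amine at that carbon would behave as chloro or as hydrogen does. They also leave open whether a longer chain in place of the methoxymethyl group would alter the size of the step.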